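A Shorter Hydroxyalkyl Chain and Membrane Permeability

This account rests on a few compounds, and the source may have more. Where it says the series, first, only, none or still open, it means among the compounds named here.

compound 1 `COc1ccc(-c2c(-c3ccc(OC)cc3)n(Cc3ccccc3)c3ncn(CCCO)c(=N)c23)cc1`: > 1000 10^-6 cm/s
compound 2 `COc1ccc(Cn2c(-c3ccccc3)c(-c3ccccc3)c3c(=N)n(CCO)cnc32)cc1`: > 1000 10^-6 cm/s

In an ADME assay for permeability, using PAMPA, with a stated time of 30 min, at pH 7.4 (a higher number here means that the compound crosses the layer faster, a lower number that the compound crosses the layer more slowly), compound 1 gives > 1000 10^-6 cm/s, which is a limit of the assay rather than a number. Compound 2 gives > 1000 10^-6 cm/s, likewise a limit. Both sit at the limit of > 1000 10^-6 cm/s in this assay, at which 2 of the 2 values shown sit. Compound 3 `COc1ccc(-c2c(-c3ccc(OC)cc3)n(Cc3ccccc3)c3ncn(CCO)c(=N)c23)cc1` differs from compound 1 by hydroxy in place of hydroxymethyl on a saturated chain carbon, two bonds along the chain from an aromatic nitrogen. Within the data shown here, no measured pair shows this change, so the expectation rests on compound 2, which carries the shorter chain and gives > 1000 10^-6 cm/s. The step from compound 1 to compound 3 is therefore expected to be a number no higher from compound 1 to compound 3 (the limit leaves the size open), none beyond the scatter. Compound 3 is expected to give 1000 10^-6 cm/s, between 500 10^-6 cm/s and 2000 10^-6 cm/s, most likely reported again only as a limit.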

Compound 3, apparent permeability: > 1000 10^-6 cm/s
Compound 3 ended at the assay's limit; the forecaster's own chance of this, stated with the estimate: 85%; the middle value sits exactly at the limit.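

Compound 1 and compound 3 both sit at a limit rather than a number, so no step between them can be read: the limit of > 1000 10^-6 cm/s in this assay, at which 3 of the 3 values shown sit.

The compounds shown leave open whether 3-hydroxypropyl and 2-hydroxyethyl differ at all in this assay.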